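The source may hold more compounds than are shown below. What is called first, only, known or untested is meant among the compounds shown, and "the series" means these compounds.

Measured so far in a functional assay on the whole organism for inhibition, with Lemna aequinoctialis as the target, with a stated time of 7 days, tested at 500 ug/mL; on this read-out higher numbers stand for more inhibition of growth at the one concentration tested and lower numbers for less inhibition of growth:
compound 1 `O=C1Nc2ccc(F)cc2/C1=N/NC(=S)Nc1ccccc1`: 70%
compound 2 `O=C1Nc2ccc(F)cc2/C1=N/NC(=S)Nc1cccc(C(F)(F)F)c1`: 30%
compound 3 `O=C1Nc2ccc(F)cc2/C1=N/NC(=S)Nc1cccc(F)c1`: 30%

Compound 3 sits level with compound 2, no change at the digits printed from compound 2 to compound 3 (within the scatter), and the pair are together the lowest of the three; the gap is a number 40 percentage points lower from compound 1 to compound 3 (beyond the scatter).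

Compound 4 `O=C1Nc2ccc(F)cc2/C1=N/NC(=S)Nc1c(F)cccc1F` is the next step: 2,6-difluorophenyl in place of 3-fluorophenyl on an amide-type nitrogen.

Bearing on it: a number 40 percentage points lower from compound 1 to compound 2 (beyond the scatter) and a number 40 percentage points lower from compound 1 to compound 3 (beyond the scatter) show that putting one substituent on the unsubstituted phenyl of compound 1 cuts inhibition sharply, while no change at the digits printed from compound 2 to compound 3 (within the scatter) shows that exchanging one substituent for another leaves the number where it is. Among the measured compounds shown here, no measured step adds a second fluorine or moves fluorine on this ring. Compound 4 is therefore expected to stay within scatter of compound 3, no change at the digits printed from compound 3 to compound 4 (within the scatter), estimated at 30% (range 10% to 55%).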

Compound 4, percent growth inhibition at one concentration: 30%
The estimate for compound 4 equals the measured number at the digits printed, and the stated range covers the measured number.
By their numbers in this assay, from the lowest: compounds 2, 3 and 4 (each within the scatter of the next); then compound 1.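

In this assay, 2,6-difluorophenyl in place of 3-fluorophenyl gives no change at the digits printed from compound 3 to compound 4 (within the scatter), so the change in fluorine count and ring pattern leaves the number unmoved. With a number 40 percentage points lower from compound 1 to compound 4 (beyond the scatter), a phenyl carrying two fluorines also fails to recover the level of the unsubstituted phenyl, and all three substituted phenyls shown on this amide-type nitrogen sit apart from it. Nothing available explains this result.

On these data alone, whether a methoxy or an amine on the phenyl would keep the level of compound 1 remains open. So does whether a cyclohexyl in place of the phenyl would keep it.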